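Working notes: 3,4-diethoxyphenyl in place of 3,4-dihydroxyphenyl

The source may report more compounds than this note shows. Statements on the series, on what has been measured and on what is new or still open speak of the compounds shown alone.

Measured so far in a functional assay, read by spectrophotometry, with a stated time of 5 min; on this read-out lower numbers stand for stronger inhibition and higher numbers for weaker inhibition
- compound 1 `COc1cc(/C=C/C(=O)C(=Cc2ccc(OC)c(OC)c2)C(=O)/C=C/c2ccc(O)c(OC)c2)ccc1O` gives 6760 nM
- compound 2 `COc1cc(/C=C/C(=O)C(=Cc2ccc(O)cc2)C(=O)/C=C/c2ccc(O)c(OC)c2)ccc1O` gives 6320 nM
- compound 3 `COc1cc(/C=C/C(=O)C(=Cc2ccc(O)c(O)c2)C(=O)/C=C/c2ccc(O)c(OC)c2)ccc1O` gives 2200 nM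

Compound 3 stands lowest of the three at 2200 nM on these numbers. Compound 4 `CCOc1ccc(C=C(C(=O)/C=C/c2ccc(O)c(OC)c2)C(=O)/C=C/c2ccc(O)c(OC)c2)cc1OCC` is still unmeasured. The change 3,4-diethoxyphenyl in place of 3,4-dihydroxyphenyl on a double-bonded chain carbon bound to a double-bonded chain carbon puts 3,4-diethoxyphenyl in place of 3,4-dihydroxyphenyl on a double-bonded chain carbon bound to a double-bonded chain carbon.

The closest measured step is a 3.1-fold lower number from compound 1 to compound 3 (0.49 log units; beyond the scatter) and it is the nearest guide when read in reverse. a 2.9-fold lower number from compound 2 to compound 3 (0.46 log units; beyond the scatter) points the same way, while a 1.1-fold lower number from compound 1 to compound 2 (0.03 log units; within the scatter) shows no separation between those two compounds. Going by the values given here, no ethoxy compound has been measured, so this guide is only approximate.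

A modest step to a higher number is therefore expected in this assay. The estimate means a 3.2-fold higher number from compound 3 to compound 4 (0.50 log units; beyond the scatter) as the expected step. For compound 4 the estimated value is 7000 nM (expected range 3000 nM to 16000 nM).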

Compound 4, half-maximal inhibitory concentration: 10000 nM
For compound 4 the middle estimate is 1.4-fold (0.15 log units) below the measured one; the range from low to high includes it.
By their numbers in this assay, from the lowest: compound 3; then compounds 2, 1 and 4 (each within the scatter of the next).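

In this assay there is a 4.5-fold higher number from compound 3 to compound 4 (0.66 log units; beyond the scatter) when 3,4-diethoxyphenyl replaces 3,4-dihydroxyphenyl on this chain carbon, so the ethyl ethers do not keep the stronger inhibition seen with the free hydroxy groups. Compound 4 cannot be separated from the other two analogues, with a 1.6-fold higher number from compound 2 to compound 4 (0.20 log units; within the scatter) and a 1.5-fold higher number from compound 1 to compound 4 (0.17 log units; within the scatter) both within the scatter, so lengthening methoxy to ethoxy shows no measurable effect here. Among these four compounds only 3,4-dihydroxyphenyl stands apart at this position, and 4-hydroxyphenyl, although it keeps a hydroxy, does not separate from 3,4-diethoxyphenyl.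

Going by these compounds, whether a longer chain such as butoxy, an amine or a carboxylic acid on this aromatic ring could match compound 3 remains open. Nothing available explains why 3,4-dihydroxyphenyl stands apart.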